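The source may hold more compounds than are shown below. What is called first, only, known or untested is meant among the compounds shown, and "the series" means these compounds.

In a functional assay with Cavia porcellus as the target (on this read-out lower numbers stand for an effect already at smaller amounts and higher numbers for an effect only at larger amounts of compound), compound 1 `COC(=O)c1c(C)[nH]c(C)c1C(=O)c1ccccc1` gives 21900 nM, and compound 2 `COC(=O)c1c(C)[nH]c(C)c1C(=O)c1ccccc1Cl`, which carries a chloro group in place of a hydrogen on an aromatic carbon, gives 14000 nM. These two numbers lie within the scatter of each other, so compound 2 cannot be ranked against compound 1. Compound 3 `COC(=O)c1c(C)[nH]c(C)c1C(=O)c1cc(Cl)ccc1Cl` repeats the same kind of exchange at a new place on compound 2: chloro in place of hydrogen on an aromatic carbon. The added chloro sits para to a chloro group and meta to a large group. Among the compounds with values here, only one measured step bears on this change, a 1.6-fold lower number from compound 1 to compound 2 (0.19 log units; within the scatter), and it was made at a different place on the ring. On that single precedent, no step beyond the scatter is expected in this assay. The expected step is a 1.3-fold lower number from compound 2 to compound 3 (0.10 log units; within the scatter). For compound 3 the estimated value is 11000 nM, with an expected range from 4500 nM to 28000 nM.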

Compound 3, half-maximal effective concentration: 3980 nM
Compound 3: the middle estimate sits 2.8-fold (0.44 log units) above what was measured; the whole stated range lies above it.
By their numbers in this assay, from the lowest: compound 3; then compounds 2 and 1 (each within the scatter of the next).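

The same exchange does not read the same at both places: a 1.6-fold lower number from compound 1 to compound 2 (0.19 log units; within the scatter) stays within the scatter, whereas the chloro that sits para to a chloro group and meta to a large group gives a 3.5-fold lower number from compound 2 to compound 3 (0.55 log units; beyond the scatter) in this assay. This is the first step among these compounds to lie beyond the scatter, though it is modest in size and rests on a single pair. Nothing measured here accounts for why this place gives the larger step.

Within the data shown here, it remains open whether a chloro at this place would give a similar step on a ring without the first chloro, since only the pair with both is at hand. Also open, as far as these compounds go, is how other groups at this place would compare, such as a methoxy, an amine or a carboxylic acid.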